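Swapping a chlorinated phenyl amide for cyclopentyl: clearance outlook

A few compounds are considered here, and "the series" means these few. Any claim that something is new, unique, unknown or untested is made for them only; others in the source may bear on it.

Compound 1 `CN1C[C@H](C(=O)Nc2ccc(C(F)(F)F)cc2)[C@@H](c2ccc(/C=C/C(=O)Nc3ccccc3N)cc2)C1`: 6 mL/min/kg
Compound 2 `CN1C[C@H](C(=O)Nc2ccc(F)c(Cl)c2)[C@@H](c2ccc(/C=C/C(=O)Nc3ccccc3N)cc2)C1`: 15 mL/min/kg
Compound 3 `Cc1cc(NC(=O)[C@H]2CN(C)C[C@@H]2c2ccc(/C=C/C(=O)Nc3ccccc3N)cc2)ccc1Cl`: 15 mL/min/kg

In an in vitro ADME assay on microsomes from liver (Homo sapiens) for pharmacokinetics, read by LC-MS, with a stated time of 10 min, tested at 1 uM (a higher number here means faster removal of the compound, a lower number slower removal), compound 3 gives 15 mL/min/kg. Compound 3 is level with compound 2, no change at the digits printed from compound 2 to compound 3 (within the scatter), and these two share the highest number of the three; the step from the lowest of the three is a 2.5-fold higher number from compound 1 to compound 3 (0.40 log units; beyond the scatter). Compound 4 `CN1C[C@H](C(=O)NC2CCCC2)[C@@H](c2ccc(/C=C/C(=O)Nc3ccccc3N)cc2)C1` differs from compound 3 in one place: cyclopentyl in place of 4-chloro-3-methylphenyl on an amide-type nitrogen. Going by the values given here, none of the measured steps swaps an aromatic ring for a non-aromatic one; the known steps, a 2.5-fold higher number from compound 1 to compound 2 (0.40 log units; beyond the scatter) and a 2.5-fold higher number from compound 1 to compound 3 (0.40 log units; beyond the scatter), only trade one substituted phenyl for another and were modest. Compound 4 is therefore expected to stay close to compound 3, a step of no change at the digits printed from compound 3 to compound 4 (within the scatter). The estimate for compound 4 is 15 mL/min/kg, within 7 mL/min/kg to 32 mL/min/kg.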

Compound 4, clearance: 9 mL/min/kg
The estimate for compound 4 lay 1.7-fold (0.22 log units) above the measured number; the range from low to high includes it.
By their numbers in this assay, from the lowest: compounds 1, 4, 2 and 3 (each within the scatter of the next, the first and the last beyond it).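

Cyclopentyl is the first non-aromatic ring seen on this amide-type nitrogen, and in this assay the swap gives a 1.7-fold lower number from compound 3 to compound 4 (0.22 log units; within the scatter) and a 1.7-fold lower number from compound 2 to compound 4 (0.22 log units; within the scatter) and a 1.5-fold higher number from compound 1 to compound 4 (0.18 log units; within the scatter) against the three phenyl amides. At this position, then, a substituted phenyl ring is not needed for clearance to stay in the range of these compounds. No measurement shown gives a reason for this result.

Still open, from the compounds shown here alone, is whether a piperidine ring, an open chain such as butyl, or a cyclopentyl carrying a carboxylic acid would stay in that range.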